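Replacing Phenyl with 4-Hydroxybutyl on the Amine Chain

The source may report more compounds than this note shows. Statements on the series, on what has been measured and on what is new or still open speak of the compounds shown alone.

compound 1 `CSc1nc(NCCCc2ccccc2)c2ccccc2n1`: 50600 nM
compound 2 `CSc1nc(NCCCCc2ccccc2)c2ccccc2n1`: > 100000 nM (a limit)
compound 3 `CSc1nc(NCc2ccccc2)c2ccccc2n1`: 37900 nM

In a functional assay on HTB-54 cells (Homo sapiens) for cytotoxicity, read by MTT assay, with a stated time of 72 h (on this read-out higher numbers stand for weaker inhibition of growth and lower numbers for stronger inhibition of growth), compound 3 gives 37900 nM, the lowest of the two plain numbers, though compound 1 with 50600 nM lies within the scatter of it. For compound 2 the assay reports only a limit, > 100000 nM. Among the measured compounds shown here, the one measured step, an at least 1.9-fold higher number from compound 1 to compound 2 (0.29 log units; that floor lies within the scatter), lengthens the chain and sits at the floor set by the limit of > 100000 nM in this assay, at which 1 of the 3 values shown sits. Compound 4 `CSc1nc(NCCCCCO)c2ccccc2n1` arises from compound 3 by 4-hydroxybutyl in place of phenyl on a saturated chain carbon bound to a nitrogen on an aromatic ring. For the measured compounds named here, no measured step swaps the ring for a hydroxyl-bearing chain, so the expectation rests loosely on the chain-lengthening step: a modest rise in this assay, a 1.8-fold higher number from compound 3 to compound 4 (0.27 log units; within the scatter), is expected. Compound 4 is estimated at 70000 nM, within 25000 nM to 200000 nM.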

Compound 4, concentration for 50% growth inhibition: 31400 nM
The estimate for compound 4 lay 2.2-fold (0.35 log units) above the measured number, and the stated range covers the measured number.
By their numbers in this assay, from the lowest: compounds 4, 3 and 1 (each within the scatter of the next). At a limit, above all of these: compound 2.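

In this assay compound 4 carries no ring on its chain, yet it stays within the scatter of the two ring-bearing compounds that have plain numbers (a 1.2-fold lower number from compound 3 to compound 4 (0.08 log units; within the scatter)) and (a 1.6-fold lower number from compound 1 to compound 4 (0.21 log units; within the scatter)). Only against compound 2 does a gap beyond the scatter appear (an at least 3.1-fold lower number from compound 2 to compound 4 (0.50 log units; beyond the scatter)). That step is a floor, as compound 2 is known only by a limit: the limit of > 100000 nM in this assay, at which 1 of the 4 values shown sits.

The compounds shown leave open whether the hydroxyl matters at all. A plain pentyl chain, or an amine or carboxylic acid at the chain end, would test that.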